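From butoxy to azido on a shared core

This account rests on a few compounds, and the source may have more. Where it says the series, first, only, none or still open, it means among the compounds named here.

Measured in a functional assay on KB cells (Homo sapiens) for inhibition; a lower number here means a stronger inhibitor, a higher number a weaker inhibitor:
Compound 1 `CC(=O)OC1C(CF)OC(n2c(Cl)nc3cc(Cl)c(Cl)cc32)C1OC(C)=O` (100000 nM)
Compound 2 `CC(=O)OC1C(CBr)OC(n2c(Cl)nc3cc(Cl)c(Cl)cc32)C1OC(C)=O` (60000 nM)
Compound 3 `CCCCOC[C@H]1OC(n2c(Cl)nc3cc(Cl)c(Cl)cc32)[C@H](O)[C@@H]1O` (60000 nM)

Compound 2 and compound 3 give the same number, and compound 1 lies within the scatter of both. Compound 4 `[N-]=[N+]=NC[C@H]1OC(n2c(Cl)nc3cc(Cl)c(Cl)cc32)[C@H](O)[C@@H]1O` has not yet been measured. It differs from compound 3 in one place, with azido in place of butoxy on a saturated chain carbon bound to a saturated ring carbon.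

For the measured compounds named here, only one measured step bears on this change (a 1.7-fold lower number from compound 1 to compound 2 (0.22 log units; within the scatter)). It is bromo in place of fluoro on the same kind of carbon, a different exchange that offers only loose guidance. With that step inside the scatter and compound 3 at (60000 nM), no step beyond the scatter is expected in this assay, and no direction can be named. The estimated step is small (no change at the digits printed from compound 3 to compound 4 (within the scatter)). For compound 4 the expected value is (60000 nM), with an estimated range from (25000 nM) to (130000 nM).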

Compound 4, half-maximal inhibitory concentration: 70000 nM
The estimate for compound 4 lay 1.2-fold (0.07 log units) below the measured number; measured number inside the range.
By their numbers in this assay, from the lowest: compounds 2, 3, 4 and 1 (each within the scatter of the next).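

In this assay, azido in place of butoxy on a saturated chain carbon bound to a saturated ring carbon gives a 1.2-fold higher number from compound 3 to compound 4 (0.07 log units; within the scatter) and stays within the scatter. For the compounds shown here, the only earlier step on this kind of carbon, bromo in place of fluoro, came from the acetylated compounds, whereas this one extends the reading to the compounds with free hydroxyl groups: exchanging a group of 5 heavy atoms for one of 3 heavy atoms, with the butyl chain gone, produces no step beyond the scatter. Nothing available accounts for this result.

The compounds shown leave open whether an amine, a carboxylic acid or a longer chain on this carbon would move the number beyond the scatter. They also leave open whether fluoro or bromo there would read the same with the free hydroxyl groups of compound 3 in place of the acetate groups of compound 1.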